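Extending the aryl group: a hydroxynaphthyl analogue of compound 2

A few compounds are considered here, and "the series" means these few. Any claim that something is new, unique, unknown or untested is made for them only; others in the source may bear on it.

Of the compounds shown here, three sharing one core have been tested in a functional assay on Ehrlich cells (Mus musculus) for cytotoxicity, read by trypan blue exclusion, with a stated time of 2 h, tested at 10 ug/mL; on this read-out lower numbers stand for a weaker effect and higher numbers for a stronger effect at the one concentration tested. Compound 1 `N#CC1=C(N)N(c2ccc(S(N)(=O)=O)cc2)C2=C(CCCC2)C1/C=C/c1ccccc1` gives 50% in this assay. Compound 2 `COc1ccc(C2C(C#N)=C(N)N(c3ccc(S(N)(=O)=O)cc3)C3=C2CCCC3)cc1` gives 50%, and compound 3 `N#CC1=C(N)N(c2ccc(S(N)(=O)=O)cc2)C2=C(CCCC2)C1c1ccc([N+](=O)[O-])cc1` gives 0%. Compound 2 therefore stands level with compound 1 at the digits shown, and the two together are the highest of the three numbers; compound 3 is the furthest from compound 2, as the step of a number 50 percentage points lower from compound 2 to compound 3 (beyond the scatter) shows.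

Compound 4 `N#CC1=C(N)N(c2ccc(S(N)(=O)=O)cc2)C2=C(CCCC2)C1c1c(O)ccc2ccccc12` has not yet been measured. It differs from compound 2 in one place: 2-hydroxynaphthalen-1-yl in place of 4-methoxyphenyl on a saturated ring carbon.

Among the compounds with values here, two measured steps bear on this. The step of no change at the digits printed from compound 1 to compound 2 (within the scatter) shows that one aryl group in place of another on that carbon left the read-out unchanged, while the step of a number 50 percentage points lower from compound 2 to compound 3 (beyond the scatter) shows that a nitro group in place of methoxy removed the effect entirely. Within the data shown here, no measured compound carries a hydroxyl or a second aromatic ring at this position, so the expectation is uncertain and leans only slightly downward.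

Compound 4 is therefore expected to give 40%, within a range of 0% to 70%, which would correspond to an expected step of a number 10 percentage points lower from compound 2 to compound 4 (within the scatter).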

Compound 4, a percentage reported as activity, at one concentration (the size of the read-out at that concentration, not a potency): 10%
For compound 4 the middle estimate is 30 percentage points above the measured one, and the stated range covers the measured number.
By their numbers in this assay, from the lowest: compounds 3 and 4 (each within the scatter of the next); then compounds 1 and 2 (each within the scatter of the next).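

In this assay, the earlier compounds had shown a loss of effect on this saturated ring carbon only with 4-nitrophenyl. The step of a number 40 percentage points lower from compound 2 to compound 4 (beyond the scatter) and the step of a number 40 percentage points lower from compound 1 to compound 4 (beyond the scatter) now show a large loss with 2-hydroxynaphthalen-1-yl, a group without a nitro group, while the step of a number 10 percentage points higher from compound 3 to compound 4 (within the scatter) leaves compound 3 and compound 4 indistinguishable, so two quite different aryl groups give a similarly low reading here. Nothing available accounts for this loss.

This change brings in a second aromatic ring and a hydroxyl group together, so the compounds shown cannot separate the contribution of each. Plain naphthalen-1-yl and 4-hydroxyphenyl would pull the two apart, and an amine on the phenyl ring remains a further open case.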